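Trifluoromethyl in place of tert-butyl: compound 3

The source may report more compounds than this note shows. Statements on the series, on what has been measured and on what is new or still open speak of the compounds shown alone.

Among the compounds with values here, compound 2 `CN(C)Cc1cn(CC(=O)Nc2sc3c(c2C(N)=O)CCCC3)nc1C(C)(C)C` gives 316 nM in an assay on isolated protein with metabotropic glutamate receptor 1 (Homo sapiens) as the target (a lower number here means that less compound is needed, a higher number that more compound is needed for the effect), the lower of the two numbers so far; compound 1 `CC(C)(C)c1nn(CC(=O)Nc2sc3c(c2C(N)=O)CCCC3)cc1CNC1CC1` gives 1580 nM, and the step of a 5.0-fold lower number from compound 1 to compound 2 (0.70 log units; beyond the scatter) is the only one measured. Compound 3 `CN(C)Cc1cn(CC(=O)Nc2sc3c(c2C(N)=O)CCCC3)nc1C(F)(F)F` carries trifluoromethyl in place of tert-butyl on an aromatic carbon. Within the data shown here, no measured step touches this position; the step from compound 1 to compound 2 altered the (dimethylamino)methyl side and says nothing about the tert-butyl. The direction of a 1.6-fold higher number from compound 2 to compound 3 (0.20 log units; within the scatter) is therefore expected to be open, with a change near the scatter. For compound 3 the estimate is 500 nM, with a range from 150 nM to 1600 nM.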

Compound 3, half-maximal effective concentration: 501 nM
Compound 3: the middle estimate sits 1.0-fold (0.00 log units) below what was measured; the range from low to high includes it.
By their numbers in this assay, from the lowest: compounds 2 and 3 (each within the scatter of the next); then compound 1.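

Trifluoromethyl in place of tert-butyl on an aromatic carbon gives a 1.6-fold higher number from compound 2 to compound 3 (0.20 log units; within the scatter) in this assay. Within the data shown here, this is the first change to stay within the scatter, so compound 2 and compound 3 cannot be told apart at this position. Nothing available bears on the reason for this result.

As far as these compounds go, whether this position also accepts a hydrogen, a phenyl ring or a carboxylic acid remains open. Also open, from the compounds shown here alone, is whether cyclopropylamino in place of dimethylamino gives a similar step with trifluoromethyl present.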